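Moving the furan attachment on an amide carbonyl

This account rests on a few compounds, and the source may have more. Where it says the series, first, only, none or still open, it means among the compounds named here.

- Compound 1 `CCCCCCCCCCCC[C@@H](O)[C@H]1CC[C@H]([C@H](O)CCCCCCCCCCNC(=O)c2cccs2)O1` gives 1820 nM
- Compound 2 `CCCCCCCCCCCC[C@@H](O)[C@H]1CC[C@H]([C@H](O)CCCCCCCCCCNC(=O)c2ccco2)O1` gives 100000 nM

In a functional assay on St-4 cells (Homo sapiens) for inhibition, read by colorimetric assay and sulforhodamine B assay, with a stated time of 48 h (on this read-out higher numbers stand for weaker inhibition of growth and lower numbers for stronger inhibition of growth), compound 2 has the higher number of the two, at 100000 nM, so it inhibits growth more weakly than compound 1 does. Compound 3 `CCCCCCCCCCCC[C@@H](O)[C@H]1CC[C@H]([C@H](O)CCCCCCCCCCNC(=O)c2ccoc2)O1` differs from compound 2 in one place: furan-3-yl in place of furan-2-yl on a carbonyl carbon. In words, furan-3-yl stands in place of furan-2-yl on a carbonyl carbon. For the measured compounds named here, one measured step bears on this change, made at the same carbonyl carbon: a 55-fold higher number from compound 1 to compound 2 (1.74 log units; beyond the scatter). Going by the values given here, that step was large, so swapping the ring here can matter, yet no measured pair shows what moving the furan attachment does. A moderate step towards a lower number is expected in this assay, smaller than that one, though no change beyond the scatter remains possible. The expected step is a 6.7-fold lower number from compound 2 to compound 3 (0.82 log units; beyond the scatter). For compound 3 the estimated value is 15000 nM, with an expected range of 2000 nM to 100000 nM.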

Compound 3, concentration for 50% growth inhibition: 97700 nM
Beside the measured number, compound 3's estimate is 6.5-fold (0.81 log units) below it; measured number inside the range.
By their numbers in this assay, from the lowest: compound 1; then compounds 3 and 2 (each within the scatter of the next).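

In this assay, the point at which the furan ring joins the carbonyl carbon makes no clear difference: the result is a 1.0-fold lower number from compound 2 to compound 3 (0.01 log units; within the scatter), so furan-2-yl and furan-3-yl cannot be told apart here. The gap to the thiophene compound also holds for the second furan, with a 54-fold higher number from compound 1 to compound 3 (1.73 log units; beyond the scatter), so the large loss of growth inhibition seen with furan-2-yl is not tied to that one attachment point. Nothing available here explains why thiophen-2-yl stands apart from both furans.

On these data alone, whether thiophen-3-yl would keep the stronger inhibition of thiophen-2-yl remains open. So does how a phenyl or pyridine ring on the same carbonyl carbon would compare with the thiophene and the two furans.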